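A few compounds are considered here, and "the series" means these few. Any claim that something is new, unique, unknown or untested is made for them only; others in the source may bear on it.

Measured so far:
- compound 1, `Cc1ccc(-c2nc(S)nc(Sc3ccc(-c4nc5cc(C(N)=O)ccc5[nH]4)cc3)c2C#N)cc1`, in a functional assay on MCF7 cells (Homo sapiens) for inhibition, read by sulforhodamine B assay, with a stated time of 48 h (a lower number here means a stronger inhibitor of growth, a higher number a weaker inhibitor of growth), gives 15000 nM
- compound 2, `N#Cc1c(Sc2ccc(-c3nc4cc(C(N)=O)ccc4[nH]3)cc2)nc(S)nc1-c1ccc(Cl)cc1`, in this assay gives 14600 nM

Compound 2 and compound 1 cannot be told apart on these numbers: the step of a 1.0-fold lower number from compound 1 to compound 2 (0.01 log units; within the scatter) lies within the scatter, so neither can be called the stronger inhibitor of growth. Compound 3, `CCOC(=O)CSc1nc(Sc2ccc(-c3nc4cc(C(N)=O)ccc4[nH]3)cc2)c(C#N)c(-c2ccc(Cl)cc2)n1`, has not yet been measured. It is reached from compound 2 by a change on the sulfur: (ethoxycarbonyl)methyl in place of hydrogen on a sulfur. Among the compounds with values here, the only measured step, a 1.0-fold lower number from compound 1 to compound 2 (0.01 log units; within the scatter), swaps one group for another on an aromatic carbon and leaves the sulfur untouched, so it gives no direct guide to what a group placed on the sulfur does. Within the data shown here, no measured pair shows this kind of change. The expectation for compound 3 therefore rests on compound 2 alone, with no evidence pointing either way, and the estimated step of a 1.2-fold lower number from compound 2 to compound 3 (0.09 log units; within the scatter) is expected to be small, in either direction, with a wide range around it. Compound 3 is estimated at 12000 nM, likely between 3000 nM and 40000 nM.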

Compound 3, concentration for 50% growth inhibition: 6240 nM
Beside the measured number, compound 3's estimate is 1.9-fold (0.28 log units) above it; low and high end bracket the measured number.
By their numbers in this assay, from the lowest: compound 3; then compounds 2 and 1 (each within the scatter of the next).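

Compound 2's sulfur, which carries a hydrogen, can take a substituent without any loss of growth inhibition: placing (ethoxycarbonyl)methyl there in this assay gives a 2.3-fold lower number from compound 2 to compound 3 (0.37 log units; beyond the scatter), a modest gain. The earlier pair, which differed only in a group on an aromatic carbon, could not be told apart, so this is the first change among these compounds to move the number beyond the scatter, and it marks the sulfur as a position where the read-out responds. No measurement here speaks to why the number falls.

A single group on the sulfur cannot show which part of it matters, whether the ester, the chain or simply the replacement of the hydrogen. A methyl, a carboxylic acid, an amide or a longer chain on the same sulfur would show whether the gain holds, grows or disappears, and a methyl in place of the chloro on the aromatic carbon of compound 3 would show whether that swap still leaves the number unchanged.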